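Substituted phenyl swap on the amide of compound 1

This account rests on a few compounds, and the source may have more. Where it says the series, first, only, none or still open, it means among the compounds named here.

Going by the values given here, compound 1 `O=C(COc1ccc2cc(/C=C3/SC(=O)NC3=O)ccc2c1)Nc1cccc(Cl)c1` is one of two compounds measured in an assay on isolated protein for inhibition of histone deacetylase 4 (Homo sapiens), with a stated time of 1 h; on this read-out lower numbers stand for stronger inhibition and higher numbers for weaker inhibition; compound 1 gives 3800 nM, the highest of the two numbers. Its nearest neighbour is compound 2 `Cc1cc(NC(=O)COc2ccc3cc(/C=C4/SC(=O)NC4=O)ccc3c2)no1`, which in this assay gives 1700 nM. Among the compounds with values here, the single measured step, a 2.2-fold lower number from compound 1 to compound 2 (0.35 log units; beyond the scatter), puts 5-methyl-1,2-oxazol-3-yl in place of 3-chlorophenyl on the amide-type nitrogen.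

Compound 3 `Cc1cc(Br)ccc1NC(=O)COc1ccc2cc(/C=C3/SC(=O)NC3=O)ccc2c1` is not yet measured. It differs from compound 1 as follows: 4-bromo-2-methylphenyl in place of 3-chlorophenyl on an amide-type nitrogen. This change keeps one six-membered aromatic ring of carbon only on the amide-type nitrogen, whereas the measured step exchanges that ring for 5-methyl-1,2-oxazol-3-yl, so that step bears on compound 3 only as an indication that the group on this nitrogen shifts the number by a modest amount. Within the data shown here, no measured step swaps one substituted phenyl for another. The step expected in this assay is a 1.3-fold lower number from compound 1 to compound 3 (0.10 log units; within the scatter), small and not clearly beyond the scatter. For compound 3 the estimate in this assay is 3000 nM, with a range from 1200 nM to 8000 nM.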

Compound 3, half-maximal inhibitory concentration: 550 nM
Estimate against measurement, compound 3: 5.5-fold (0.74 log units) above; measured number outside the range, below it.
By their numbers in this assay, from the lowest: compound 3; then compound 2; then compound 1.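

In this assay, exchanging one substituted phenyl for another on the amide-type nitrogen gives a clear step (a 6.9-fold lower number from compound 1 to compound 3 (0.84 log units; beyond the scatter)), so the pattern of substituents on this ring matters and not only the type of ring. Compound 3 also lies lower than the 5-methyl-1,2-oxazol-3-yl compound (a 3.1-fold lower number from compound 2 to compound 3 (0.49 log units; beyond the scatter)), while compound 1 gives the highest number of the three although it too carries a six-membered aromatic ring of carbon only on this nitrogen; a ring of that kind therefore does not by itself set the number, and the order of the three follows the substituents on the group. No supporting measurement at hand accounts for the step from 3-chlorophenyl to 4-bromo-2-methylphenyl.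

Compound 3 brings in the bromine and the methyl together, so the compounds shown do not tell how much of the step belongs to each, as neither 4-bromophenyl nor 2-methylphenyl appears on its own. As far as these compounds go, how a carboxylic acid or an amine on the phenyl ring would read in this assay also remains open.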